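Ethoxymethyl in place of formyl on a double-bonded ring carbon

The source may report more compounds than this note shows. Statements on the series, on what has been measured and on what is new or still open speak of the compounds shown alone.

Compounds measured in a functional assay for inhibition of nuclear factor NF-kappa-B complex (Homo sapiens); on this read-out higher numbers stand for weaker inhibition and lower numbers for stronger inhibition:
compound 1 `COc1ccc2c(c1)OC(c1cc(OC)c(OC)c(OC)c1)C(CO)=C2`: > 50000 nM, a limit of the assay.
compound 2 `COc1ccc2c(c1)OC(c1cc(OC)c(OC)c(OC)c1)C(C(=O)N(C)OC)=C2`: 11700 nM.
compound 3 `COc1ccc2c(c1)OC(c1cc(OC)c(OC)c(OC)c1)C(C=O)=C2`: 13500 nM.

Compound 3 sits alongside compound 2, a 1.2-fold higher number from compound 2 to compound 3 (0.06 log units; within the scatter). The two carbonyl-bearing compounds part from the alcohol: an at least 3.7-fold lower number from compound 1 to compound 3 (0.56 log units; beyond the scatter) and an at least 4.2-fold lower number from compound 1 to compound 2 (0.63 log units; beyond the scatter), the former only a limit (the limit of > 50000 nM in this assay, at which 1 of the 3 values shown sits).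

Compound 4 `CCOCC1=Cc2ccc(OC)cc2OC1c1cc(OC)c(OC)c(OC)c1` differs from compound 3 by ethoxymethyl in place of formyl on a double-bonded ring carbon. The nearest measured step is the reverse of the formyl-for-hydroxymethyl exchange; an ethoxymethyl is likewise a carbonyl-free single-bonded substituent, so a move back toward a weaker number, and possibly toward the limit, is expected. Compound 4 is estimated at 30000 nM, range 8000 nM to 100000 nM, the step of a 2.2-fold higher number from compound 3 to compound 4 (0.35 log units; beyond the scatter) being an expectation only.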

Compound 4, half-maximal inhibitory concentration: 21300 nM
Compound 4: middle estimate off by 1.4-fold (0.15 log units), on the high side; measured number inside the range.
By their numbers in this assay, from the lowest: compounds 2, 3 and 4 (each within the scatter of the next). At a limit, above all of these: compound 1.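

Ethoxymethyl on this double-bonded ring carbon cannot be told apart from the two carbonyl-bearing groups in this assay: a 1.6-fold higher number from compound 3 to compound 4 (0.20 log units; within the scatter) and a 1.8-fold higher number from compound 2 to compound 4 (0.26 log units; within the scatter), so compounds 2, 3 and 4 show that a carbonyl is not needed here. Ethyl in place of hydrogen on the hydroxymethyl oxygen is itself a readable change, an at least 2.3-fold lower number from compound 1 to compound 4 (0.37 log units; beyond the scatter). Compound 1 stands at a limit, so that step is only a bound: the limit of > 50000 nM in this assay, at which 1 of the 4 values shown sits.

As far as these compounds go, whether an amine, a carboxylic acid or a longer ether chain on this carbon would move the number beyond the scatter stays open. From the compounds shown here alone, the true value of compound 1 also stays open.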